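Trifluoromethylphenyl for Chlorophenyl on the Shared Core

This account rests on a few compounds, and the source may have more. Where it says the series, first, only, none or still open, it means among the compounds named here.

Compound 1 `COc1nc(-c2cccc(Cl)c2)ccc1[C@@H](c1ccccc1)[C@@](O)(CCN(C)C)c1cccc2ccccc12` is the starting point of this step. In a toxicity assay on HeLa cells (Homo sapiens) for cytotoxicity (on this read-out lower numbers stand for higher toxicity in this test and higher numbers for lower toxicity in this test), compound 1 gives "nd" (no result reported), which means that no result is reported, so there is no number to stand on. Two close relatives of the shared core do carry numbers. Compound 2 `COc1ncc(-c2ccccc2)cc1[C@@H](c1ccccc1)[C@@](O)(CCN(C)C)c1cccc2ccccc12` gives 30.4 ug/mL in this assay, and compound 3 `COc1ncc(-c2ccccc2)cc1[C@@H](c1ccccc1)[C@@](O)(CCN(C)C)c1cccc(F)c1F` gives 28.1 ug/mL. Among the compounds with values here, the one step between measured compounds, a 1.1-fold lower number from compound 2 to compound 3 (0.03 log units; within the scatter), concerns another part of the molecule and lies within the scatter. Compound 4 `COc1nc(-c2ccc(C(F)(F)F)cc2)ccc1[C@@H](c1ccccc1)[C@@](O)(CCN(C)C)c1cccc2ccccc12` differs from compound 1 by 4-(trifluoromethyl)phenyl in place of 3-chlorophenyl on an aromatic carbon. Within the data shown here, no measured pair alters the group at that position, so the only guide is that compound 2 and compound 3 sit close together in this assay despite a change elsewhere on the core. On that basis no step beyond the scatter is expected from compound 1 to compound 4 in this assay, in either direction, although the missing number for compound 1 leaves the starting point open. Compound 4 is therefore expected to give about 27 ug/mL in this assay, with an estimated range from 10 ug/mL to 70 ug/mL.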

Compound 4, half-maximal cytotoxic concentration: > 64 ug/mL
Compound 4 gave a limit, no number; the forecaster's own chance of this, stated with the estimate: 10%; middle value at least 2.3-fold (0.37 log units) from the limit.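

In this assay compound 4 gives > 64 ug/mL, which is a limit and not a number. Within the data shown here, compound 1 has no reported result, so no step from compound 1 to compound 4 can be read. The compounds shown leave open what 4-(trifluoromethyl)phenyl in place of 3-chlorophenyl does to the number in this assay.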